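Difluorophenyl replacing methoxyphenyl in an M5 carbamate series

The source may hold more compounds than are shown below. What is called first, only, known or untested is meant among the compounds shown, and "the series" means these compounds.

Compound 1 `Cc1ccc(CCCOC(=O)N(c2ccccc2)C2CN3CCC2CC3)cc1F` — 130 nM
Compound 2 `COc1ccc(CCCOC(=O)N(c2ccccc2)C2CN3CCC2CC3)cc1` — 640 nM

Among the measured compounds shown here, in an assay on CHO cells for displacement of a labelled ligand from muscarinic acetylcholine receptor M5 (Homo sapiens), read by scintillation counting, with a stated time of 2 h (a lower number here means a stronger inhibitor, a higher number a weaker inhibitor), compound 2 gives the higher of the two numbers measured so far, with compound 1 the nearer neighbour at a 4.9-fold higher number from compound 1 to compound 2 (0.69 log units; beyond the scatter). Compound 3 `O=C(OCCCc1ccc(F)c(F)c1)N(c1ccccc1)C1CN2CCC1CC2` differs from compound 2 by 3,4-difluorophenyl in place of 4-methoxyphenyl on a saturated chain carbon, three bonds along the chain from an oxygen next to a carbonyl group. For the measured compounds named here, the only step that bears on this change is a 4.9-fold higher number from compound 1 to compound 2 (0.69 log units; beyond the scatter), where a ring bearing fluorine and methyl gave the lower number. Compound 3 is therefore expected to move back toward compound 1, by a 3.2-fold lower number from compound 2 to compound 3 (0.51 log units; beyond the scatter). The estimate for compound 3 is 200 nM, within 70 nM to 600 nM.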

Compound 3, inhibition constant: 100 nM
For compound 3 the middle estimate is 2.0-fold (0.30 log units) above the measured one; low and high end bracket the measured number.
By their numbers in this assay, from the lowest: compounds 3 and 1 (each within the scatter of the next); then compound 2.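

In this assay, 3,4-difluorophenyl in place of 4-methoxyphenyl gives a 6.4-fold lower number from compound 2 to compound 3 (0.81 log units; beyond the scatter) on this saturated chain carbon, so a second ring without methoxy also stands clear of compound 2. Fluoro in place of methyl on an aromatic carbon gives a 1.3-fold lower number from compound 1 to compound 3 (0.11 log units; within the scatter) and does not separate the two fluorinated rings here. Among the compounds shown, none goes against this pairing of the two rings.

Going by these compounds, whether unsubstituted phenyl, 4-fluorophenyl or a longer chain would match these rings remains open. No measurement shown explains the difference between these rings.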